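Cytotoxicity notes on the quinoline-diamine series: furan to catechol ether

A few compounds are considered here, and "the series" means these few. Any claim that something is new, unique, unknown or untested is made for them only; others in the source may bear on it.

Measured so far in an ADME assay on HepG2 cells (Homo sapiens) for cytotoxicity, read by luminescence, CellTiter-Glo and ATP content, with a stated time of 72 h; on this read-out lower numbers stand for an effect already at smaller amounts and higher numbers for an effect only at larger amounts of compound:
- compound 1, `COc1ccc(Oc2ccc3c(NCCCNCc4cccc(OC)c4O)ccnc3c2)cc1`: 5500 nM
- compound 2, `COc1cccc(CNCCCNc2ccnc3cc(Cc4ccc(C#N)cc4)ccc23)c1O`: 7150 nM
- compound 3, `CC(C)(C)c1ccc(-c2ccc3c(NCCCNCc4ccco4)ccnc3c2)cc1`: 3150 nM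

Compound 3 gives the lowest of the three numbers in this assay. Its nearest neighbour is compound 1, whose number is higher but within the scatter; its furthest is compound 2, whose number is higher and beyond the scatter. Within the measured set only one single-point step exists, a 1.3-fold higher number from compound 1 to compound 2 (0.11 log units; within the scatter), which concerns the group on the aromatic carbon of the core and not the benzylic end of the chain.

Compound 4, `COc1cccc(CNCCCNc2ccnc3cc(-c4ccc(C(C)(C)C)cc4)ccc23)c1O`, is not yet measured. Against compound 3 the change is 2-hydroxy-3-methoxyphenyl in place of furan-2-yl on a saturated chain carbon bound to an amine nitrogen. For the measured compounds named here, no measured step covers this exchange directly. What can be said is that compound 1 and compound 2, which both carry the entering 2-hydroxy-3-methoxybenzyl group, gave numbers at or above that of compound 3, which carries the (furan-2-yl)methyl group; the two ends of the molecule otherwise differ between those compounds, so this is a loose indication only.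

On that basis the expected step is a 1.4-fold higher number from compound 3 to compound 4 (0.15 log units; within the scatter), that is, no change beyond the scatter or at most a modest rise. Compound 4 is estimated at 4500 nM, with a range from 2000 nM to 10000 nM.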

Compound 4, half-maximal effective concentration: 690 nM
For compound 4 the middle estimate is 6.5-fold (0.81 log units) above the measured one, outside the stated range (below it).
By their numbers in this assay, from the lowest: compound 4; then compounds 3, 1 and 2 (each within the scatter of the next, the first and the last beyond it).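

In this assay, for the compounds shown here, 2-hydroxy-3-methoxyphenyl in place of furan-2-yl on a saturated chain carbon bound to an amine nitrogen gives a 4.6-fold lower number from compound 3 to compound 4 (0.66 log units; beyond the scatter), the first reading of this exchange with the rest of the molecule held constant, and the number moves down, not up. Going by these compounds alone, with the 2-hydroxy-3-methoxybenzyl group held, the group on the aromatic carbon also proves to matter: 4-(tert-butyl)phenyl in place of 4-cyanobenzyl gives a 10-fold lower number from compound 2 to compound 4 (1.02 log units; beyond the scatter), and in place of 4-methoxyphenoxy it gives an 8.0-fold lower number from compound 1 to compound 4 (0.90 log units; beyond the scatter), whereas the one earlier step on that carbon stayed within the scatter. Among these four compounds, the lowest number therefore appears only where 4-(tert-butyl)phenyl and 2-hydroxy-3-methoxybenzyl occur together, in compound 4.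

Nothing shown accounts for the size of these steps. Still open, on these data alone, is whether the ring hydroxyl, the methoxy or the benzyl ring itself carries the exchange, which plain benzyl and 2-methoxybenzyl end groups would separate, and whether it holds with a longer chain or with 4-cyanobenzyl on the aromatic carbon.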